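A ring exchanged on the carbonyl of compound 2

The compounds below may be only part of what the source reports. "The series", "measured", "known", "first", "only" and "open" are said of these compounds alone.

Measured in an ADME assay (liver) for metabolic stability, with Liver microsome (Rattus norvegicus) as the target, using microsomes; on this read-out lower numbers stand for slow clearance and higher numbers for fast clearance:
- compound 1 `c1ccc(COc2ccc3c(c2)CCN(C2CCC2)CC3)cc1`: > 50 mL.min-1.g-1 (a limit of the assay)
- compound 2 `O=C(N1CCOCC1)N1CCC(Oc2ccc3c(c2)CCN(C2CCC2)CC3)CC1`: 1.1 mL.min-1.g-1
- compound 3 `c1cc2c(cc1OCC1CCNCC1)CCN(C1CCC1)CC2`: 0.7 mL.min-1.g-1

Compound 2 stands at 1.1 mL.min-1.g-1. Its value lies within the scatter of compound 3 at 0.7 mL.min-1.g-1. For compound 1 the value > 50 mL.min-1.g-1 is a limit.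

Compound 4 `Cc1cc(C(=O)N2CCC(Oc3ccc4c(c3)CCN(C3CCC3)CC4)CC2)no1` differs from compound 2 in one place: 5-methyl-1,2-oxazol-3-yl in place of morpholin-4-yl on a carbonyl carbon. In words, 5-methyl-1,2-oxazol-3-yl stands in place of morpholin-4-yl on a carbonyl carbon.

Among the measured compounds shown here, the only measured step is an at least 71-fold lower number from compound 1 to compound 3 (1.85 log units; beyond the scatter), with piperidin-4-yl in place of phenyl on a saturated chain carbon bound to an oxygen on an aromatic ring. That is a different place and a different exchange, and its size rests on (the limit of > 50 mL.min-1.g-1 in this assay, at which 1 of the 3 values shown sits), so the size does not carry over. The incoming ring here is aromatic, whereas an at least 71-fold lower number from compound 1 to compound 3 (1.85 log units; beyond the scatter) removed an aromatic ring, which suggests only a slight expected lean toward faster clearance.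

In this assay the estimated step is small, a 1.6-fold higher number from compound 2 to compound 4 (0.21 log units; within the scatter), and none clearly beyond the scatter is expected. Compound 4 is estimated at 1.8 mL.min-1.g-1, with an expected range of 0.6 mL.min-1.g-1 to 6 mL.min-1.g-1.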

Compound 4, intrinsic clearance in microsomes: 3.5 mL.min-1.g-1
The estimate for compound 4 lay 1.9-fold (0.29 log units) below the measured number; low and high end bracket the measured number.
By their numbers in this assay, from the lowest: compounds 3 and 2 (each within the scatter of the next); then compound 4. At a limit, above all of these: compound 1.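

In this assay, among the compounds shown here, the ring on the carbonyl carbon turns out to matter: exchanging morpholin-4-yl for 5-methyl-1,2-oxazol-3-yl gives a 3.2-fold higher number from compound 2 to compound 4 (0.50 log units; beyond the scatter) and takes the pair beyond the scatter, a difference the earlier compounds could not show, as their only step lay in another place. The two groups hold the same heavy atoms in number and kind, so the change in the read-out arises without any change in that count; what differs is a six-membered non-aromatic ring against a five-membered aromatic ring, with one more hydrogen-bond acceptor counted on the incoming group. The results shown offer no measured property that would explain this step.

The compounds shown leave open whether the higher number follows the aromatic ring itself or its methyl group, which an unsubstituted 1,2-oxazol-3-yl on the same carbonyl carbon would help to separate. Going by these compounds, it also remains open how an open-chain group on that carbon, such as dimethylamino, would compare with either ring.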